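Chloro to Hydroxy at the Aromatic Carbon

This account rests on a few compounds, and the source may have more. Where it says the series, first, only, none or still open, it means among the compounds named here.

Measured compounds:
compound 1, `COc1ccc(/C=N/NC(=S)N2CCNCC2)cc1` — 1620 nM
compound 2, `S=C(N/N=C/c1ccc(Cl)cc1)N1CCNCC1` — 1600 nM

Compound 1 and compound 2 share one core and differ only at a single aromatic carbon, where compound 2 carries chloro in place of the methoxy of compound 1. In a functional assay on HBL-100 cells (Homo sapiens) for antiproliferative activity, read by MTT assay, with a stated time of 72 h (a lower number here means a stronger inhibitor, a higher number a weaker inhibitor), compound 2 gives 1600 nM, and the step of a 1.0-fold lower number from compound 1 to compound 2 (0.01 log units; within the scatter) shows that the two numbers cannot be told apart. Compound 2 thus stands together with compound 1, with no separation beyond the scatter on the numbers shown.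

Compound 3, `Oc1ccc(/C=N/NC(=S)N2CCNCC2)cc1`, is the next member of the series. It differs from compound 2 by hydroxy in place of chloro on an aromatic carbon. For the measured compounds named here, the only measured step that bears on this change is the exchange at the same carbon from compound 1 to compound 2, which was within the scatter. Going by the values given here, no measured step involves hydroxy. From this, the step of a 1.3-fold higher number from compound 2 to compound 3 (0.10 log units; within the scatter) is expected to stay within the scatter, with no clear direction. Compound 3 is therefore estimated at 2000 nM in this assay, with a range from 900 nM to 4500 nM.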

Compound 3, half-maximal inhibitory concentration: 180 nM
For compound 3 the middle estimate is 11-fold (1.05 log units) above the measured one, and the stated range ends above it.
By their numbers in this assay, from the lowest: compound 3; then compounds 2 and 1 (each within the scatter of the next).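

The position para to a large group on the aromatic ring is not indifferent to its substituent in this assay, as the exchange of chloro for methoxy had suggested: hydroxy in place of chloro gives an 8.9-fold lower number from compound 2 to compound 3 (0.95 log units; beyond the scatter), whereas the earlier exchange gave only a 1.0-fold lower number from compound 1 to compound 2 (0.01 log units; within the scatter). Hydrogen in place of methyl on the oxygen gives a 9.0-fold lower number from compound 1 to compound 3 (0.95 log units; beyond the scatter), so the free hydroxy separates from methoxy as well as from chloro, and the loss of that one methyl is enough to make compound 3 the strongest of the three inhibitors shown. No supporting measurement is available to explain why hydroxy stands apart from the other two groups.

The three compounds leave open whether this gain belongs to hydroxy alone or would also appear with an amine or a carboxylic acid on the same carbon. They also leave open whether hydroxy would give a similar step at another carbon of the aromatic ring, or whether a second hydroxy on the ring would add to it.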